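Chloro in Place of Methoxy: Expecting Compound 3

The source may hold more compounds than are shown below. What is called first, only, known or untested is meant among the compounds shown, and "the series" means these compounds.

Compound 1 `CCCCNC(=O)NS(=O)(=O)c1ccc(-n2nc(-c3ccc(OC)cc3)ccc2=O)cc1` gives 25.6% in a functional assay on the whole organism (blood, strain Wistar albino) for inhibition, with Rattus norvegicus as the target, read by colorimetric assay, with stated times of 15 min and 90 min, at a dose of 20 mg/kg by the oral route; a higher number here means more inhibition at the dose given (going by the name of the read-out), a lower number less inhibition.
Compound 2 `Cc1ccc(-c2ccc(=O)n(-c3ccc(S(=O)(=O)NC(=O)NC4CCCCC4)cc3)n2)cc1` gives 110% in this assay.

Of the two measured numbers, compound 1 stands lowest; compound 2 sits far higher, beyond the scatter, but the two differ in more than one place, so no single change can be credited with that gap. Compound 3 `CCCCNC(=O)NS(=O)(=O)c1ccc(-n2nc(-c3ccc(Cl)cc3)ccc2=O)cc1` has not yet been measured. It differs from compound 1 by chloro in place of methoxy on an aromatic carbon. Going by the values given here, no pair of measured compounds isolates this change, so its size is uncertain. In this assay a modest upward step is expected, though a step of no more than the scatter would not surprise. Compound 3 is expected to give 40%, within a range from 10% to 80%. The estimated step of a number 14.4 percentage points higher from compound 1 to compound 3 (beyond the scatter) is thus a moderate rise.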

Compound 3, a percentage reported as inhibition, in the whole organism at one dose (the size of the read-out at that dose, not a potency): 100%
Beside the measured number, compound 3's estimate is 60 percentage points below it, outside the stated range (above it).
By their numbers in this assay, from the lowest: compound 1; then compounds 3 and 2 (each within the scatter of the next).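

Chloro in place of methoxy, on an aromatic carbon para to a large group, is the first change here that can be read on its own, and in this assay it gives a number 74.4 percentage points higher from compound 1 to compound 3 (beyond the scatter) with the rest of compound 1 unchanged. This shows that the group at this position can by itself move the inhibition seen at the single oral dose by a large amount, which the earlier gap between two compounds differing in more than one place could not show. Nothing available here explains why the swap of 4-methoxyphenyl to 4-chlorophenyl has this effect.

As far as these compounds go, it remains open whether the rise depends on chloro itself or mainly on the removal of methoxy, a question that fluoro or trifluoromethyl at the same position could address. From the compounds shown here alone, it is also open whether the same swap would have a similar effect on a different urea side chain.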